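Acyl chain truncation in the acetylated thioglycoside amide series

The source may report more compounds than this note shows. Statements on the series, on what has been measured and on what is new or still open speak of the compounds shown alone.

Measured compounds in a functional assay on MDA-MB-231 cells (Homo sapiens) for cytotoxicity, read by MTT assay, with a stated time of 24 h; on this read-out lower numbers stand for stronger inhibition and higher numbers for weaker inhibition:
compound 1 `CCCCCCCCCCCCCCCCCC(=O)Nc1nnc(S[C@@H]2O[C@H](COC(C)=O)[C@H](OC(C)=O)[C@H](OC(C)=O)[C@H]2OC(C)=O)s1` gives 23600 nM
compound 2 `CCCCCCCC/C=C\CCCCCCCC(=O)Nc1nnc(S[C@@H]2O[C@H](COC(C)=O)[C@H](OC(C)=O)[C@H](OC(C)=O)[C@H]2OC(C)=O)s1` gives 23600 nM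
compound 3 `CCCCCCCCCCCCCCCC(=O)Nc1nnc(S[C@@H]2O[C@H](COC(C)=O)[C@H](OC(C)=O)[C@H](OC(C)=O)[C@H]2OC(C)=O)s1` gives 25400 nM

Compound 3 sits within the scatter of both others: a 1.1-fold higher number from compound 1 to compound 3 (0.03 log units; within the scatter) and a 1.1-fold higher number from compound 2 to compound 3 (0.03 log units; within the scatter). Compound 4 `C=CCCCCCCCCC(=O)Nc1nnc(S[C@@H]2O[C@H](COC(C)=O)[C@H](OC(C)=O)[C@H](OC(C)=O)[C@H]2OC(C)=O)s1` differs from compound 3 by vinyl in place of heptyl on a saturated chain carbon, eight bonds along the chain from a carbonyl carbon. For the measured compounds named here, two measured steps bear on this change. Removing carbon from the chain end, a 1.1-fold higher number from compound 1 to compound 3 (0.03 log units; within the scatter), left the number unmoved, and placing a double bond in the chain, no change at the digits printed from compound 1 to compound 2 (within the scatter), did likewise. Going by the values given here, the present cut is much deeper than either, and no measured compound carries a chain this short, so the expected step of a 1.1-fold higher number from compound 3 to compound 4 (0.04 log units; within the scatter) is small but carries a wide range. Compound 4 is therefore expected to give 28000 nM in this assay, estimated between 12000 nM and 65000 nM.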

Compound 4, half-maximal inhibitory concentration: 60900 nM
Estimate against measurement, compound 4: 2.2-fold (0.34 log units) below, and the stated range covers the measured number.
By their numbers in this assay, from the lowest: compounds 1, 2 and 3 (each within the scatter of the next); then compound 4.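

In this assay, this position first shows a response once vinyl replaces heptyl: (a 2.4-fold higher number from compound 3 to compound 4 (0.38 log units; beyond the scatter)) lies beyond the scatter, whereas the earlier chain changes all stayed within it. The step is of similar size against the two longest chains, with (a 2.6-fold higher number from compound 2 to compound 4 (0.41 log units; beyond the scatter)) and (a 2.6-fold higher number from compound 1 to compound 4 (0.41 log units; beyond the scatter)) both also beyond the scatter.

Compound 4 combines a shorter chain with a terminal double bond, so the compounds shown do not separate these two changes; a saturated chain of the same length would address that. No available evidence explains why the number rises.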